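The source may report more compounds than this note shows. Statements on the series, on what has been measured and on what is new or still open speak of the compounds shown alone.

Measured so far:
- compound 1 `CCn1c(C(=O)NCCN(C)C)ccc1C(CC)(CC)c1ccc(OCCC(O)(CC)CC)c(C)c1` gives 240 nM
- compound 2 `CCn1c(C(=O)NCC#N)ccc1C(CC)(CC)c1ccc(OCCC(O)(CC)CC)c(C)c1` gives > 50000 nM (a limit)
- compound 3 `C#CC(C)OC(=O)c1ccc(C(CC)(CC)c2ccc(OCCC(O)(CC)CC)c(C)c2)n1CC` gives > 50000 nM (a limit)

All of these readings come from a functional assay on HepG2 cells (Homo sapiens) for antiproliferative activity, read by MTT assay, with a stated time of 48 h; a higher number here means a weaker inhibitor, a lower number a stronger inhibitor. Compound 3 stands at > 50000 nM, which is a limit and not a number. It sits at the limit of > 50000 nM in this assay, at which 2 of the 3 values shown sit.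

Compound 4 `CCn1c(C(=O)Nc2cccc(C(F)(F)F)c2)ccc1C(CC)(CC)c1ccc(OCCC(O)(CC)CC)c(C)c1` changes one place, with (3-(trifluoromethyl)phenyl)amino in place of (1-methylprop-2-yn-1-yl)oxy on a carbonyl carbon. Like compound 2 and compound 3, it lacks the (2-(dimethylamino)ethyl)amino group of compound 1. Both measured departures from that group gave large steps (an at least 200-fold higher number from compound 1 to compound 2 (2.31 log units; beyond the scatter); an at least 200-fold higher number from compound 1 to compound 3 (2.31 log units; beyond the scatter)). The comparison closest to this change offers no size to work from (a step that the two limits leave unreadable from compound 2 to compound 3). Compound 4 is therefore expected to stay weak, near the limit, with at most a modest move towards a lower number. The expected change is an at least 2.0-fold lower number from compound 3 to compound 4 (0.30 log units; that floor lies within the scatter). For compound 4 the estimated value is 25000 nM (expected range 4000 nM to 60000 nM).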

Compound 4, half-maximal inhibitory concentration: > 50000 nM
Compound 4: only a limit was reported (the forecaster's own chance of this, stated with the estimate: 55%); at least 2.0-fold (0.30 log units) between middle value and limit.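

In this assay compound 4 gives > 50000 nM, which is a limit and not a number. Replacing the (2-(dimethylamino)ethyl)amino group with (3-(trifluoromethyl)phenyl)amino, which brings in an aromatic ring, gives an at least 200-fold higher number from compound 1 to compound 4 (2.31 log units; beyond the scatter), so this third departure from that group also gives a large loss, while the steps among the three limit compounds cannot be read. Compound 1 remains the only compound shown with a readable value, and the others gather at one limit: the limit of > 50000 nM in this assay, at which 3 of the 4 values shown sit.

Going by these compounds, it stays open how much of the (2-(dimethylamino)ethyl)amino group is needed for activity. A primary amine on the same chain, a longer chain ending in dimethylamino, or a carboxylic acid at the end of that chain would each help to answer this.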